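Swapping the chlorinated arm for a methylated one

The source may report more compounds than this note shows. Statements on the series, on what has been measured and on what is new or still open speak of the compounds shown alone.

Compound 2, with the structure `CC1=CC[C@@H]([C@@](C)(O)CCCC(C)(C)NC(=S)N/N=C\c2ccc(Cl)cc2)CC1`, is the stronger of the two measured compounds: in a functional assay on MCF7 cells (Homo sapiens) for cytotoxicity, read by sulforhodamine B assay (a higher number here means a weaker inhibitor of growth, a lower number a stronger inhibitor of growth), compound 2 gives 15800 nM. Among the measured compounds shown here, its only neighbour is compound 1, with the structure `COc1ccc(/C=N\NC(=S)NC(C)(C)CCC[C@](C)(O)[C@@H]2CC=C(C)CC2)cc1`, which in this assay gives 94900 nM. For the measured compounds named here, the one measured step, a 6.0-fold lower number from compound 1 to compound 2 (0.78 log units; beyond the scatter), came from exchanging a chloro for a methoxy on an aromatic carbon, so the aromatic arm of the shared core does move the read-out.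

Compound 3, with the structure `CC1=CC[C@@H]([C@@](C)(O)CCCC(C)(C)NC(=S)N/N=C(/C)c2ccccc2)CC1`, differs from compound 2 by a group of 9 heavy atoms (8 carbon, 1 nitrogen; one six-membered aromatic ring of carbon only) in place of a group of 9 heavy atoms (7 carbon, 1 nitrogen, 1 chlorine; one six-membered aromatic ring of carbon only), on an amide-type nitrogen. In words, the chlorine on the aromatic ring is gone and a methyl now sits on the carbon of the double bond outside the ring. Going by the values given here, no measured pair covers either of these two changes, so the step can only be judged loosely. Since removing a ring substituent moves away from what made compound 2 stand out in the step of a 6.0-fold lower number from compound 1 to compound 2 (0.78 log units; beyond the scatter), a weaker result is expected, on the order of a 2.5-fold higher number from compound 2 to compound 3 (0.40 log units; beyond the scatter) in this assay. Compound 3 is therefore estimated at 40000 nM, within a range of 12000 nM to 130000 nM.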

Compound 3, concentration for total growth inhibition: 62900 nM
Compound 3: the middle estimate sits 1.6-fold (0.20 log units) below what was measured; measured number inside the range.
By their numbers in this assay, from the lowest: compound 2; then compounds 3 and 1 (each within the scatter of the next).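

The step of a 4.0-fold higher number from compound 2 to compound 3 (0.60 log units; beyond the scatter) in this assay shows that the standing of compound 2 does not carry over to an arm that has lost the chlorine and gained a methyl on the carbon of the double bond outside the ring. Compared with the methoxy arm, the same arm gives a 1.5-fold lower number from compound 1 to compound 3 (0.18 log units; within the scatter), so these two arms cannot be told apart in this assay, and among the three compounds only the chlorinated one, compound 2, stands out as the strongest inhibitor of growth. No measurement here offers an explanation for the difference between the chlorinated arm and the other two.

From the compounds shown here alone, compound 3 carries two changes at once, so the share of the lost chlorine and the share of the added methyl remain unknown; an arm with both the chlorine and that methyl, or with neither, would separate them. Going by these compounds, it also remains open whether another ring substituent, such as a bromine, a nitrile or a trifluoromethyl group, would match the chlorine or go beyond it.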